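The compounds below may be only part of what the source reports. "The series", "measured", "known", "first", "only" and "open" are said of these compounds alone.

In an assay on isolated protein for activation of cGMP-dependent protein kinase 1 (Homo sapiens), read by ADP-Glo, with stated times of 120 min and 40 min (on this read-out lower numbers stand for an effect already at smaller amounts and higher numbers for an effect only at larger amounts of compound), compound 1 `Cn1cc(CN2CCC[C@H](OCc3cc(Cl)cc(Cl)c3)[C@@H]2c2ccccc2)cn1` gives 110000 nM. Compound 2 `Clc1cc(Cl)cc(CO[C@H]2CCCN(Cc3ccccn3)[C@H]2c2ccccc2)c1` reaches only a limit of this assay, > 200000 nM. Compound 3 `Clc1cc(Cl)cc(CO[C@H]2CCCN(Cc3ncco3)[C@H]2c2ccccc2)c1` likewise reaches only a limit of this assay, > 200000 nM. The steps of an at least 1.8-fold higher number from compound 1 to compound 2 (0.25 log units; that floor lies within the scatter) and an at least 1.8-fold higher number from compound 1 to compound 3 (0.25 log units; that floor lies within the scatter) both rest on (the limit of > 200000 nM in this assay, at which 2 of the 3 values shown sit), and a step that the two limits leave unreadable from compound 2 to compound 3 cannot be read. Compound 3 thus stands at the limit, where one further value shown also sits. Compound 4 `COc1cc(C(=O)O)ccc1CN1CCC[C@H](OCc2cc(Cl)cc(Cl)c2)[C@@H]1c1ccccc1` differs from compound 3 by 4-carboxy-2-methoxyphenyl in place of 1,3-oxazol-2-yl on a saturated chain carbon bound to an amine nitrogen in a ring. For the measured compounds named here, none of the measured steps exchanges a five-membered aromatic ring for a 4-carboxy-2-methoxyphenyl group, so they give no direction, and the scatter alone frames the expectation. Compound 4 is therefore estimated at 150000 nM, within 50000 nM to 400000 nM. The expected step is an at least 1.3-fold lower number from compound 3 to compound 4 (0.12 log units; that floor lies within the scatter), in no direction beyond the scatter.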

Compound 4, half-maximal effective concentration: 62000 nM
The estimate for compound 4 lay 2.4-fold (0.38 log units) above the measured number; the range from low to high includes it.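

In this assay, the place on a saturated chain carbon bound to an amine nitrogen in a ring now shows a readable change: 4-carboxy-2-methoxyphenyl gives an at least 3.2-fold lower number from compound 3 to compound 4 (0.50 log units; beyond the scatter) and an at least 3.2-fold lower number from compound 2 to compound 4 (0.50 log units; beyond the scatter). Both steps rest on a limit: the limit of > 200000 nM in this assay, at which 2 of the 4 values shown sit. Against 1-methyl-1H-pyrazol-4-yl, the same group gives a 1.8-fold lower number from compound 1 to compound 4 (0.25 log units; within the scatter), so these two are not told apart.

On these data alone, whether the carboxylic acid or the methoxy group carries the change stays open. So does what an unsubstituted phenyl ring, an amine or a longer chain would do at this place.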